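This account rests on a few compounds, and the source may have more. Where it says the series, first, only, none or still open, it means among the compounds named here.

In a functional assay on A549/CDDP cells (Homo sapiens) for antiproliferative activity, read by MTT assay, with a stated time of 72 h (on this read-out higher numbers stand for weaker inhibition and lower numbers for stronger inhibition), compound 1 (`Cc1nc(C)c(/C=C/C(=O)/C=C/c2ccccc2O)nc1C`) gives 3900 nM and compound 2 (`Cc1nc(C)c(/C=C/C(=O)/C=C/c2cccc(O)c2)nc1C`) gives 3700 nM on the shared core, so compound 2 stands level with compound 1 within the scatter and the pair sets no order. The next structure is compound 3 (`Cc1nc(C)c(/C=C/C(=O)/C=C/c2ccc(O)cc2)nc1C`), and the change from compound 2 is 4-hydroxyphenyl in place of 3-hydroxyphenyl on a double-bonded chain carbon bound to a double-bonded chain carbon at the one place already varied, a double-bonded chain carbon bound to a double-bonded chain carbon. Going by the values given here, only one measured step bears on this swap, the move from 2-hydroxyphenyl to 3-hydroxyphenyl at that same place. Among the compounds with values here, no compound with 4-hydroxyphenyl has been read yet, so the support is thin. Within the data shown here, with a 1.1-fold lower number from compound 1 to compound 2 (0.02 log units; within the scatter) as the only guide, no step beyond the scatter is expected in this assay in either direction. The expected step is a 1.1-fold lower number from compound 2 to compound 3 (0.02 log units; within the scatter) and it remains an estimate. For compound 3 the estimated value is 3500 nM with an expected range from 1500 nM to 8000 nM as its bounds.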

Compound 3, half-maximal inhibitory concentration: 4790 nM
The estimate for compound 3 lay 1.4-fold (0.14 log units) below the measured number; the measured number falls inside the stated range.
By their numbers in this assay, from the lowest: compounds 2, 1 and 3 (each within the scatter of the next).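

With 4-hydroxyphenyl now read on a double-bonded chain carbon bound to a double-bonded chain carbon, the series in this assay holds three hydroxyphenyl groups at this place, and the new comparisons give a 1.3-fold higher number from compound 2 to compound 3 (0.11 log units; within the scatter) and a 1.2-fold higher number from compound 1 to compound 3 (0.09 log units; within the scatter). The 4-hydroxyphenyl swap therefore separates from neither of the other two hydroxyphenyl groups, so compounds 1, 2 and 3 read level and take no order by where the hydroxyl group stands on the ring. No supporting data are available to explain this level reading.

Still open, from the compounds shown here alone, is whether a methoxy group, an amine or a carboxylic acid in place of the hydroxyl group would give a step beyond the scatter at this place, and whether a plain phenyl group would read level with these three compounds. Also open is whether a longer chain on the shared core would shift the number beyond the scatter, since every compound shown here varies only in the hydroxyphenyl group.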